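From amino to acetamido at a limit

This account rests on a few compounds, and the source may have more. Where it says the series, first, only, none or still open, it means among the compounds named here.

Measured so far in an ADME assay on Vero cells (Chlorocebus sabaeus) for cytotoxicity (a lower number here means that less compound is tolerated, a higher number that more compound is tolerated), are these compounds:
Compound 1 `O=[N+]([O-])c1ccc(-c2nc3cc(Cl)c(Cl)cc3[nH]2)cc1` gives >= 100000 nM as a limit
Compound 2 `Nc1ccc(-c2nc3cc(Cl)c(Cl)cc3[nH]2)cc1` gives >= 100000 nM as a limit

Compound 2 has no number of its own, since its >= 100000 nM is a limit and nothing more. The next compound is compound 3 `CC(=O)Nc1ccc(-c2nc3cc(Cl)c(Cl)cc3[nH]2)cc1` with its amino turned to acetamido. That difference is counted as acetyl in place of hydrogen on a nitrogen on an aromatic ring and reads in words as acetyl in place of hydrogen on a nitrogen on an aromatic ring. Only a step that the two limits leave unreadable from compound 1 to compound 2 bears on this place, and it gives no size to carry over. The remaining evidence is the limit of >= 100000 nM in this assay, at which 2 of the 2 values shown sit, and no measured number. No step beyond the scatter is therefore expected in this assay in either direction, and compound 3 will most likely be reported as a limit again. The expected change is a number no higher from compound 2 to compound 3 (the limit leaves the size open) and no more. For compound 3 the estimate is 100000 nM with an expected range from 50000 nM to 200000 nM in this reading.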

Compound 3, half-maximal cytotoxic concentration: > 100000 nM
Compound 3: a limit, no number; the forecaster's own chance of this, stated with the estimate: 80%; the middle value lies on the limit itself.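

In this assay compound 3 gives > 100000 nM, which is a limit and not a number. Within the data shown here, compound 1 and compound 2 also stand at limits, and no step from either of them to compound 3 can be read. The compounds shown leave open what concentration of any of the three would actually produce a half-maximal cytotoxic effect in this assay.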